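Compound 4: 5-chloropyridin-2-yl on the shared core

This account rests on a few compounds, and the source may have more. Where it says the series, first, only, none or still open, it means among the compounds named here.

In a physicochemical assay for solubility, read by HPLC, in phosphate buffer, measured as kinetic solubility, at pH 7.4 (a lower number here means a less soluble compound, a higher number a more soluble compound), compound 1 (`CCC(=O)c1cc(-c2ccc(S(N)(=O)=O)cc2)n(-c2ccc(Cl)cc2)n1`) gives 41900 nM and compound 2 (`CCC(=O)c1cc(-c2ccc(S(N)(=O)=O)cc2)n(-c2ccc(F)cc2)n1`) gives 96800 nM. Compound 3 (`CCC(=O)c1cc(-c2ccc(S(N)(=O)=O)cc2)n(-c2ccccc2)n1`) gives 47200 nM, and the two steps that place it are a 1.1-fold higher number from compound 1 to compound 3 (0.05 log units; within the scatter) and a 2.1-fold lower number from compound 2 to compound 3 (0.31 log units; beyond the scatter). Compound 4 (`CCC(=O)c1cc(-c2ccc(S(N)(=O)=O)cc2)n(-c2ccc(Cl)cn2)n1`) carries 5-chloropyridin-2-yl in place of phenyl on an aromatic nitrogen. Among the measured compounds shown here, the closest measured step is a 1.1-fold higher number from compound 1 to compound 3 (0.05 log units; within the scatter), an exchange of chloro and hydrogen, and it points to no sizeable step from the chloro alone. For the measured compounds named here, no measured compound carries a hetero atom in that ring, so that part of the change is untested. The expected step in this assay is a 1.1-fold higher number from compound 3 to compound 4 (0.03 log units; within the scatter), with none expected beyond the scatter. Compound 4 is estimated at 50000 nM, with an expected range of 22000 nM to 110000 nM.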

Compound 4, solubility: 33700 nM
Compound 4: the middle estimate sits 1.5-fold (0.17 log units) above what was measured; the range from low to high includes it.
By their numbers in this assay, from the lowest: compounds 4, 1 and 3 (each within the scatter of the next); then compound 2.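

In this assay, a ring nitrogen added to the 4-chlorophenyl group gives no step beyond the scatter, with a 1.2-fold lower number from compound 1 to compound 4 (0.09 log units; within the scatter), and adding the chloro and ring nitrogen to phenyl likewise stays within it, with a 1.4-fold lower number from compound 3 to compound 4 (0.15 log units; within the scatter). Among the compounds shown here, the only new step beyond the scatter is a 2.9-fold lower number from compound 2 to compound 4 (0.46 log units; beyond the scatter), so compound 2 alone stands apart from the 5-chloropyridin-2-yl group. Nothing at hand accounts for these steps.

Still open, on these data alone, is pyridin-2-yl without the chloro, which would read the ring nitrogen on its own. Also open, as far as these compounds go, is a fluoro in place of that chloro on the same ring, which would show whether the separation of compound 2 carries over.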